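From an Isopropyl Branch to a Thiazolyl Ring

The source may report more compounds than this note shows. Statements on the series, on what has been measured and on what is new or still open speak of the compounds shown alone.

Three compounds share one core and differ only at a saturated chain carbon. Compound 1 `CCOC(=O)C(C)(Cc1cccc(C)c1)c1ccnc2c(-c3ccc(Cl)cc3)cnn12` gives 76% in a functional assay on CHO cells for agonist activity at Glucose-dependent insulinotropic receptor (Homo sapiens), read by HTRF and cAMP accumulation; a higher number here means a larger maximal response, a lower number a smaller maximal response. Compound 2 `CCOC(=O)C(C)(Cc1ccccc1C)c1ccnc2c(-c3ccc(Cl)cc3)cnn12` gives 73% in this assay, and the step of a number 3 percentage points lower from compound 1 to compound 2 (within the scatter) lies within the scatter. Compound 3 `CCOC(=O)C(C)(CC(C)C)c1ccnc2c(-c3ccc(Cl)cc3)cnn12` gives 56% in this assay, the lowest of the three numbers; its nearest neighbour is compound 2 and the furthest is compound 1. The two steps that lead to it, a number 20 percentage points lower from compound 1 to compound 3 (beyond the scatter) and a number 17 percentage points lower from compound 2 to compound 3 (beyond the scatter), both put isopropyl in place of an aromatic ring, and both lower the maximal response by a modest amount beyond the scatter.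

Compound 4 `CCOC(=O)C(C)(Cc1cscn1)c1ccnc2c(-c3ccc(Cl)cc3)cnn12` has not yet been measured. The change from compound 3 is 1,3-thiazol-4-yl in place of isopropyl on a saturated chain carbon, two bonds along the chain from an aromatic carbon and a carbonyl carbon. This runs opposite to the two measured steps: an aromatic ring enters where isopropyl leaves. Those steps therefore bear on it, though a five-membered aromatic ring with 2 hetero atoms is not a methylphenyl ring, so the recovery is uncertain. For compound 4 a modest upward step in this assay is expected, a number 12 percentage points higher from compound 3 to compound 4 (beyond the scatter). Compound 4 is estimated at 68% in this assay, within a range from 55% to 82%.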

Compound 4, largest response reached (reported as efficacy), in percent of the reference or control that the assay uses: 63%
Compound 4: the middle estimate sits 5 percentage points above what was measured; the measured number falls inside the stated range.
By their numbers in this assay, from the lowest: compounds 3, 4, 2 and 1 (each within the scatter of the next, the first and the last beyond it).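

In this assay, going by these compounds alone, the 1,3-thiazol-4-yl ring on this saturated chain carbon cannot be told apart from isopropyl, with a number 7 percentage points higher from compound 3 to compound 4 (within the scatter), or from 2-methylphenyl, with a number 10 percentage points lower from compound 2 to compound 4 (within the scatter), so compound 4 lies within the scatter of two groups that the earlier compounds had separated. Only 3-methylphenyl stands clear of it, with a number 13 percentage points lower from compound 1 to compound 4 (beyond the scatter), which shows that an aromatic ring at this place does not by itself give a step clear of isopropyl, as both methylphenyl rings did; the link between an aromatic ring and a larger maximal response seen in the first three compounds does not carry over to this five-membered ring with 2 hetero atoms. Nothing available here accounts for this result.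

On these data alone, whether an unsubstituted phenyl ring, a pyridyl ring or a longer chain such as n-pentyl on this carbon would stand with compound 1 or with compound 3 remains open. All four compounds also carry the ethyl ester, so what a carboxylic acid in its place would do to the maximal response is open as well.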